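The source may report more compounds than this note shows. Statements on the series, on what has been measured and on what is new or still open speak of the compounds shown alone.

Measured compounds:
Compound 1, `CC(C)(N)C(=O)N[C@@H]1CCc2ccccc2N(Cc2ccc(-c3ccccc3CNC(N)=O)cc2)C1=O`, gives 21 nM in a functional assay (Pituitary gland cell) with Rattus norvegicus as the target; on this read-out lower numbers stand for an effect already at smaller amounts and higher numbers for an effect only at larger amounts of compound.
Compound 2, `CCNC(=O)NCc1ccccc1-c1ccc(CN2C(=O)[C@H](NC(=O)C(C)(C)N)CCc3ccccc32)cc1`, gives 6 nM in this assay.

Compound 2 stands at the lowest of the two numbers in this assay. Within the data shown here, its nearest neighbour is compound 1, and the single step between them, a 3.5-fold lower number from compound 1 to compound 2 (0.54 log units; beyond the scatter), is the only measured change in this set. It comes from putting ethyl in place of hydrogen on an amide-type nitrogen at the urea end of the molecule.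

Compound 3, `CC(C)(N)C(=O)N[C@@H]1CCc2ccccc2N(Cc2ccc(-c3ccccc3CNC(=O)NCCO)cc2)C1=O`, is not yet measured. It differs from compound 2 by hydroxy in place of hydrogen on a saturated chain carbon, two bonds along the chain from an amide-type nitrogen, a change that adds hydroxy in place of hydrogen on a saturated chain carbon, two bonds along the chain from an amide-type nitrogen. Among the measured compounds shown here, no measured step covers such a swap of hydrogen for hydroxy; the one known step touches the same urea end but lengthens a chain instead, so it says little here. Without a guide, the expected step of a 1.2-fold higher number from compound 2 to compound 3 (0.07 log units; within the scatter) is none beyond the usual scatter. Compound 3 is therefore estimated at 7 nM, expected between 3 nM and 18 nM in this assay.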

Compound 3, concentration for half-maximal effect: 2 nM
Estimate against measurement, compound 3: 3.5-fold (0.54 log units) above, and the stated range ends above it.
By their numbers in this assay, from the lowest: compound 3; then compound 2; then compound 1.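

Adding one hydroxy to the ethyl group of compound 2 moves the result further in the same direction in this assay: hydroxy in place of hydrogen on a saturated chain carbon, two bonds along the chain from an amide-type nitrogen, gives a 3.0-fold lower number from compound 2 to compound 3 (0.48 log units; beyond the scatter) and so the position still responds after the ethyl has been added. Measured against the unsubstituted nitrogen, 2-hydroxyethyl in place of hydrogen gives an 11-fold lower number from compound 1 to compound 3 (1.02 log units; beyond the scatter) and is a large step, whereas the ethyl change alone was modest, so this nitrogen accepts both groups and all three compounds fit that order. The data on these compounds offer no explanation for why the hydroxy lowers the number.

On these data alone, it remains open whether the effect depends on hydroxy itself, which a methoxy or an amine at the same chain carbon would help to test, and whether a carboxylic acid there would keep the trend. A longer chain ending in hydroxy, such as 3-hydroxypropyl, would show whether the distance from the amide-type nitrogen matters as well.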